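Replacing Cyclohexylamino with Dipropylamino in a Cytotoxicity Series

This account rests on a few compounds, and the source may have more. Where it says the series, first, only, none or still open, it means among the compounds named here.

Measured so far in an ADME assay on A549 cells (Homo sapiens) for cytotoxicity, read by resazurin assay, with a stated time of 48 h (a lower number here means that less compound is tolerated, a higher number that more compound is tolerated), are two compounds:
- compound 1 `CCCCCCC(C)Nc1ccc(NC(=O)c2cc(Cl)ccc2O)c(Cl)c1` gives 23500 nM
- compound 2 `O=C(Nc1ccc(NC2CCCCC2)cc1Cl)c1cc(Cl)ccc1O` gives 68300 nM

Compound 2 has the higher of the two numbers, so more of it is tolerated. Compound 3 `CCCN(CCC)c1ccc(NC(=O)c2cc(Cl)ccc2O)c(Cl)c1` has not yet been measured. It carries dipropylamino in place of cyclohexylamino on an aromatic carbon. Among the compounds with values here, only one measured step bears on this, and it involves different groups. That step is a 2.9-fold higher number from compound 1 to compound 2 (0.46 log units; beyond the scatter) and it came with cyclohexyl in place of 1-methylheptyl on a nitrogen on an aromatic ring. There the group with a ring gave the higher number, and dipropylamino has no ring. With so little evidence, a smaller step towards a lower number is expected in this assay and the estimated step is a 1.8-fold lower number from compound 2 to compound 3 (0.25 log units; within the scatter) for this swap. For compound 3 the estimated value is 38000 nM with 15000 nM and 90000 nM as the expected lower and upper ends.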

Compound 3, half-maximal cytotoxic concentration: 10700 nM
Compound 3: middle estimate off by 3.6-fold (0.55 log units), on the high side; the whole stated range lies above it.
By their numbers in this assay, from the lowest: compound 3; then compound 1; then compound 2.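

In this assay, this position on the aromatic carbon does not treat two groups of equal heavy-atom count alike: replacing cyclohexylamino with dipropylamino gives a 6.4-fold lower number from compound 2 to compound 3 (0.81 log units; beyond the scatter). Dipropylamino also gives a 2.2-fold lower number from compound 1 to compound 3 (0.34 log units; beyond the scatter), so compound 3 has the lowest number of the three, and less of it is tolerated than of either compound with a hydrogen-bond donor on that nitrogen. No available measurement explains this drop.

The ring and the hydrogen-bond donor both disappear in this one change, so the compounds shown leave open which of the two matters. Methyl(cyclohexyl)amino, which keeps the ring but has no donor, and propylamino, which keeps the donor but has no ring, would separate these two differences.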